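Piperidine nitrogen substituent and maximal response

The source may hold more compounds than are shown below. What is called first, only, known or untested is meant among the compounds shown, and "the series" means these compounds.

Compound 2 `Cc1nc(S(C)(=O)=O)ccc1Oc1ncnc(OC2CCN(C(=S)OC(C)C)CC2)c1F` stands lowest of the two numbers in hand: in a functional assay on isolated protein for inhibition of Glucose-dependent insulinotropic receptor (Rattus norvegicus), read by HTRF and cAMP accumulation (on this read-out higher numbers stand for larger maximal responses and lower numbers for smaller maximal responses), compound 2 gives 47%, while compound 1 `Cc1nc(S(C)(=O)=O)ccc1Oc1ncnc(OC2CCN(C(=O)O[C@@H](C)CF)CC2)c1F` gives 84%. Among the measured compounds shown here, the one measured step, a number 37 percentage points lower from compound 1 to compound 2 (beyond the scatter), shows how strongly the group on the ring nitrogen sets the maximal response. Compound 3 `CCC(F)(F)C(=O)N1CCC(Oc2ncnc(Oc3ccc(S(C)(=O)=O)nc3C)c2F)CC1` is the next member, and its change from compound 2 is a group of 7 heavy atoms (4 carbon, 1 oxygen, 2 fluorine; no ring) in place of a group of 6 heavy atoms (4 carbon, 1 oxygen, 1 sulfur; no ring), on an amine nitrogen in a ring. The sulfur-bearing group that entered in compound 2 and coincided with the drop now leaves again, and a fluorine-bearing carbonyl group, nearer in make-up to the group of compound 1, takes its place. For the measured compounds named here, the only step that bears on this is a number 37 percentage points lower from compound 1 to compound 2 (beyond the scatter), so a reversal of comparable size is expected, with the step of a number 28 percentage points higher from compound 2 to compound 3 (beyond the scatter) estimated upward. Compound 3 is therefore expected to reach 75%, within 55% to 95%.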

Compound 3, largest response reached (reported as efficacy), in percent of the reference or control that the assay uses: 90%
For compound 3 the middle estimate is 15 percentage points below the measured one; the measured number falls inside the stated range.
By their numbers in this assay, from the lowest: compound 2; then compounds 1 and 3 (each within the scatter of the next).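

On the amine nitrogen in a ring, the exchange of the sulfur-bearing group for the fluorine-bearing carbonyl group gives a number 43 percentage points higher from compound 2 to compound 3 (beyond the scatter), so among these three compounds the lower maximal response in this assay goes with the group of compound 2 and not with the shared core. On the carbonyl carbon, the group with 2 fluorine and no oxygen in place of the group with 1 fluorine and 1 oxygen gives a number 6 percentage points higher from compound 1 to compound 3 (within the scatter), so the two groups are not told apart by this read-out. Nothing measured here gives a reason for either step.

Still open, on these data alone, is whether the sulfur alone carries the lower number of compound 2, a question that the oxygen counterpart of its group would settle. Also open, as far as these compounds go, is how a plain propanoyl group without fluorine, or a urea bearing a dimethylamino group, would read on the same nitrogen.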